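Adding a Hydroxy Group to a Growth Inhibitor

The source may report more compounds than this note shows. Statements on the series, on what has been measured and on what is new or still open speak of the compounds shown alone.

- Compound 1 `COc1ccc(-n2cnnc2-c2cc(OC)c(OC)c(OC)c2)cc1`: 4070 nM
- Compound 2 `COc1cc(-c2nncn2-c2ccc(N(C)C)cc2)cc(OC)c1OC`: 324 nM

Among the compounds with values here, in a functional assay on SF-539 cells (Homo sapiens) for inhibition (a higher number here means a weaker inhibitor of growth, a lower number a stronger inhibitor of growth), compound 1 gives 4070 nM, the higher of the two numbers so far, which makes it the weaker inhibitor of the pair. The next compound to be tested is compound 3 `COc1ccc(-n2cnnc2-c2cc(OC)c(OC)c(OC)c2)cc1O`. It keeps the core of compound 1 and carries one change, hydroxy in place of hydrogen on an aromatic carbon.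

Within the data shown here, only one measured step offers guidance. It is a 13-fold lower number from compound 1 to compound 2 (1.10 log units; beyond the scatter), made by putting dimethylamino in place of methoxy on an aromatic carbon. That step shows that a single change on this ring can move the number a long way. However, it swaps one group for another, whereas compound 3 gains a new group, and no measured compound carries a hydroxy group. The guide is therefore loose. A lower number is expected, by a step of similar size but with wide uncertainty.

The estimated change is a 14-fold lower number from compound 1 to compound 3 (1.13 log units; beyond the scatter). For compound 3, the expected value is 300 nM, with an estimated range of 40 nM to 2500 nM.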

Compound 3, concentration for 50% growth inhibition: 372 nM
Beside the measured number, compound 3's estimate is 1.2-fold (0.09 log units) below it, and the stated range covers the measured number.
By their numbers in this assay, from the lowest: compounds 2 and 3 (each within the scatter of the next); then compound 1.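

In this assay hydroxy in place of hydrogen gives an 11-fold lower number from compound 1 to compound 3 (1.04 log units; beyond the scatter) and so marks this aromatic carbon, ortho to a methoxy group, as a place where a single added heavy atom goes with a large change in the number. Within the data shown here, the only earlier step on this ring replaced one group with another, at the carbon that carries the methoxy group in compound 1. This step shows that the number can also move a long way when that methoxy group stays and a new group joins the ring. Nothing measured here explains why the hydroxy group has this effect.

The compounds shown leave open whether the step belongs to the hydroxy group in particular or whether another small group, such as an amine or a fluorine atom, on the same carbon would give a similar number. They also leave open whether adding the hydroxy group to compound 2, which already has dimethylamino on this ring, would lower the number further or leave it unchanged.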